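The source may report more compounds than this note shows. Statements on the series, on what has been measured and on what is new or still open speak of the compounds shown alone.

Measured in a functional assay on MCF7 cells (Homo sapiens) for inhibition, read by sulforhodamine B assay; a lower number here means a stronger inhibitor, a higher number a weaker inhibitor:
- Compound 1 `O=C1C(Nc2ccccc2F)=CC(=O)c2c1nc1n2[C@H]2OC[C@@H](O)[C@H]2OC1`: > 4000 nM (a limit)
- Compound 2 `O=C1C(NC2CCCC2)=CC(=O)c2c1nc1n2[C@H]2OC[C@@H](O)[C@H]2OC1`: > 16000 nM (a limit)
- Compound 3 `COc1ccccc1NC1=CC(=O)c2c(nc3n2[C@H]2OC[C@@H](O)[C@H]2OC3)C1=O`: 6580 nM

Compound 1 has only a limit, > 4000 nM, and not a number. Compound 2 also has only a limit, > 16000 nM. Compound 4 `O=C1C(N2CCCC2)=CC(=O)c2c1nc1n2[C@H]2OC[C@@H](O)[C@H]2OC1` is still unmeasured. It differs from compound 1 as follows: pyrrolidin-1-yl in place of (2-fluorophenyl)amino on a double-bonded ring carbon. Two measured steps stay unreadable: a step that the two limits leave unreadable from compound 1 to compound 2 and a step that the limit leaves unreadable from compound 1 to compound 3. Within the data shown here, the one readable step is an at least 2.4-fold lower number from compound 2 to compound 3 (0.38 log units; beyond the scatter), with 2-methoxyphenyl in place of cyclopentyl on an amine nitrogen. The group on compound 4 has a non-aromatic ring, as the cyclopentyl group of compound 2 does. That single step therefore points to a higher number rather than a lower one in this assay, and the result may again be only a limit. The expected step is a step that the limit leaves unreadable from compound 1 to compound 4. The estimate for compound 4 is 12000 nM, with an expected range from 3500 nM to 40000 nM.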

Compound 4, half-maximal inhibitory concentration: > 16000 nM
Compound 4 was reported as a limit; the forecaster's own chance of this, stated with the estimate: 50%; middle value at least 1.3-fold (0.12 log units) away from the limit.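

In this assay, compound 4 gives > 16000 nM, which is a limit and not a number. The readable comparison is an at least 2.4-fold higher number from compound 3 to compound 4 (0.38 log units; beyond the scatter), so replacing (2-methoxyphenyl)amino with pyrrolidin-1-yl on this double-bonded ring carbon weakens the compound, and this change also takes away the hydrogen-bond donor of the group. The other two steps to compound 4 cannot be read because both ends are limits, and compound 2 and compound 4 share the same one: the limit of > 16000 nM in this assay, at which 2 of the 4 values shown sit.

The limits leave open how far compound 1, compound 2 and compound 4 differ, so the effect of losing the donor cannot be separated from the loss of the aromatic ring. On these data alone, how a morpholin-4-yl group or an open-chain dimethylamino group would behave on this carbon also stays open.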